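The source may hold more compounds than are shown below. What is called first, only, known or untested is meant among the compounds shown, and "the series" means these compounds.

Compound 1, `O=C(CCCCCCc1ccccc1)c1nc(Br)co1`, in an assay on HEK-293T cells for inhibition of diacylglycerol lipase-alpha (Homo sapiens), read by colorimetric assay (on this read-out higher numbers stand for weaker inhibition and lower numbers for stronger inhibition), gives > 10000 nM, a limit of the assay and not a number. Compound 2, `Cc1coc(C(=O)CCCCCCc2ccccc2)n1`, in this assay gives > 10000 nM, again a limit. Compound 3, `O=C(CCCCCCc1ccccc1)c1ncno1`, in this assay gives > 10000 nM, also a limit.

Compound 3 therefore stands at the limit of the assay, and so do the other two compounds, since (the limit of > 10000 nM in this assay, at which 3 of the 3 values shown sit). Going by the values given here, the step that the two limits leave unreadable from compound 1 to compound 2 and the step that the two limits leave unreadable from compound 1 to compound 3 and the step that the two limits leave unreadable from compound 2 to compound 3 are all hidden by those limits, so no measured step has a readable size.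

Compound 4, `O=C(CCCCCCc1ccccc1)c1nc(-c2cccc(I)n2)no1`, differs from compound 3 in one place: 6-iodopyridin-2-yl in place of hydrogen on an aromatic carbon. None of the measured steps touches this position of the core of compound 3, and all three measured values are limits, so the shown data give no readable step that bears on the change. What can be said is that the change enters a 6-iodopyridin-2-yl group where compound 3 carries only a hydrogen, a larger change than any measured here. The estimate for compound 4 is therefore wide: the step of an at least 5.0-fold lower number from compound 3 to compound 4 (0.69 log units; beyond the scatter) is expected, with a substantial chance that the assay again reports only a limit. Compound 4 is estimated to give 2000 nM in this assay, within a range from 100 nM to 20000 nM.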

Compound 4, half-maximal inhibitory concentration: > 10000 nM
Compound 4: a limit, no number (the forecaster's own chance of this, stated with the estimate: 45%); middle value at least 5.0-fold (0.69 log units) from the limit.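

The step from compound 3 to compound 4 cannot be read, since both compounds give only a limit and no number, so this result adds no readable step: the limit of > 10000 nM in this assay, at which 4 of the 4 values shown sit. The compounds shown leave open which change to the shared core, if any, would give a readable number in this assay.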